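A Bromo Step Tested on Two Related Cores

The compounds below may be only part of what the source reports. "The series", "measured", "known", "first", "only" and "open" are said of these compounds alone.

The study follows four compounds in a functional assay on the whole organism with Mus musculus as the target; on this read-out lower numbers stand for an effect already at smaller amounts and higher numbers for an effect only at larger amounts of compound. Compound 1 `c1ccc(-n2nncc2-c2cccnc2)cc1` gives 39.7 mg/kg in this assay. Compound 2 `Brc1ccc(-n2nncc2-c2cccnc2)cc1`, which carries bromo in place of hydrogen on an aromatic carbon, gives 40.7 mg/kg. The step of a 1.0-fold higher number from compound 1 to compound 2 (0.01 log units; within the scatter) is within the scatter. Compound 3 `c1ccc(-n2nncc2-c2ccccn2)cc1` shares all of its atoms with compound 1, joined differently; the difference between the two cores is not broken down here. In this assay compound 3 gives 25.6 mg/kg, and its gap to compound 1 and to compound 2 is also within the scatter, so no order among the three compounds can be claimed.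

Compound 4 `Brc1ccc(-n2nncc2-c2ccccn2)cc1` has not yet been measured. It differs from compound 3 by bromo in place of hydrogen on an aromatic carbon, the same change seen between compound 1 and compound 2, made at the same kind of place. Because a 1.0-fold higher number from compound 1 to compound 2 (0.01 log units; within the scatter) left the number essentially unchanged, the corresponding step from compound 3 to compound 4 is expected to be small as well, namely a 1.0-fold higher number from compound 3 to compound 4 (0.01 log units; within the scatter). On this basis compound 4 is estimated at 26 mg/kg in this assay, with a range from 13 mg/kg to 52 mg/kg.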

Compound 4, dose for half-maximal effect: 88.6 mg/kg
Beside the measured number, compound 4's estimate is 3.4-fold (0.53 log units) below it; the whole stated range lies below it.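

In this assay, bromo in place of hydrogen on an aromatic carbon did not carry over unchanged from one core to the other, and the two steps differ: the same change on two cores in this assay, a 1.0-fold higher number (0.01 log units; within the scatter) from compound 1 to compound 2 and a 3.5-fold higher number (0.54 log units; beyond the scatter) from compound 3 to compound 4, 3.4-fold (0.53 log units) apart, beyond the scatter of two such steps. On the core of compound 3 the change gives a 3.5-fold higher number from compound 3 to compound 4 (0.54 log units; beyond the scatter), and the swap of pyridin-3-yl for pyridin-2-yl on the brominated compounds gives a 2.2-fold higher number from compound 2 to compound 4 (0.34 log units; beyond the scatter), although the two compounds without bromo, compound 1 and compound 3, lie within the scatter of each other. This shows that the effect of the bromo step depends on the core in these two pairs, but it rests on a single substituent and does not show why the steps differ or how any other change would carry across.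

The compounds shown leave open whether chloro, methoxy or an amine at the same place would follow the flat step of compound 2 or the modest step of compound 4. They also leave open whether the gap between the two steps would hold on any further core.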